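The compounds below may be only part of what the source reports. "The series", "measured", "known", "first", "only" and "open" are said of these compounds alone.

In a functional assay on MCF7 cells (Homo sapiens) for antiproliferative activity, read by sulforhodamine B assay, with a stated time of 48 h (a higher number here means a weaker inhibitor, a lower number a stronger inhibitor), compound 1 `COc1ccc(-c2ccccc2C(=O)/C=C/c2ccc(F)cc2)cc1OC` gives 7100 nM, compound 2 `COc1ccc(/C=C/C(=O)c2ccccc2-c2ccc(OC)c(OC)c2)cc1` gives 1100 nM, and compound 3 `COc1ccc(/C=C/C(=O)c2ccccc2-c2ccc(OC)c(OC)c2)cc1OC` gives 4900 nM. Compound 3 cannot be separated from compound 1, as a 1.4-fold lower number from compound 1 to compound 3 (0.16 log units; within the scatter) shows. Among the compounds with values here, the one clear gap for compound 3 is to compound 2, which holds the lowest number of the three: a 4.5-fold higher number from compound 2 to compound 3 (0.65 log units; beyond the scatter).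

The change to compound 4 `COc1ccc(OC)c(/C=C/C(=O)c2ccccc2-c2ccc(OC)c(OC)c2)c1` is 2,5-dimethoxyphenyl in place of 3,4-dimethoxyphenyl on a double-bonded chain carbon bound to a double-bonded chain carbon, with 2,5-dimethoxyphenyl in place of 3,4-dimethoxyphenyl on a double-bonded chain carbon bound to a double-bonded chain carbon. The nearest guides are changes on this same ring: a 4.5-fold higher number from compound 2 to compound 3 (0.65 log units; beyond the scatter) and a 6.5-fold lower number from compound 1 to compound 2 (0.81 log units; beyond the scatter). Both are modest, and they run in opposite directions as methoxy groups are added to the ring. Neither measures this exchange of dimethoxyphenyl patterns, so the series fixes no direction, and a modest move either way remains possible.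

The expected outcome in this assay is a 1.4-fold lower number from compound 3 to compound 4 (0.15 log units; within the scatter), which means no expected step beyond the scatter. The estimate for compound 4 is 3500 nM, with an expected range of 1100 nM to 11000 nM.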

Compound 4, half-maximal inhibitory concentration: 3100 nM
The estimate for compound 4 lay 1.1-fold (0.05 log units) above the measured number; measured number inside the range.
By their numbers in this assay, from the lowest: compound 2; then compounds 4, 3 and 1 (each within the scatter of the next, the first and the last beyond it).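

In this assay, within the data shown here, the first exchange of one dimethoxyphenyl pattern for another on the double-bonded chain carbon, 2,5-dimethoxyphenyl in place of 3,4-dimethoxyphenyl, gives no separable change (a 1.6-fold lower number from compound 3 to compound 4 (0.20 log units; within the scatter)). The 2,5-dimethoxyphenyl group still stands apart from 4-methoxyphenyl (a 2.8-fold higher number from compound 2 to compound 4 (0.45 log units; beyond the scatter)) and, unlike the 3,4-dimethoxyphenyl group of compound 3, from 4-fluorophenyl (a 2.3-fold lower number from compound 1 to compound 4 (0.36 log units; beyond the scatter)), so compound 2 keeps the lowest number in the series. No available evidence accounts for these differences.

As far as these compounds go, it remains open whether a ring carrying an amine or a carboxylic acid in place of methoxy would fall with compound 2 or with compound 4. Also open, from the compounds shown here alone, is whether a longer chain such as ethoxy would keep the numbers of the methoxy compounds.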